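The source may report more compounds than this note shows. Statements on the series, on what has been measured and on what is new or still open speak of the compounds shown alone.

Compound 1 `COc1ccc(CN(C(=O)C2CC2)c2cc(OC)c(OC)c(OC)c2)cc1O` is an amide whose carbonyl carbon carries a cyclopropyl group. In a functional assay on KYSE-450 cells (Homo sapiens) for inhibition, read by MTT assay, with a stated time of 48 h (on this read-out lower numbers stand for stronger inhibition and higher numbers for weaker inhibition), compound 1 gives 80 nM, the lowest number of the three measured compounds. Compound 2 `C#CC(=O)N(Cc1ccc(OC)c(O)c1)c1cc(OC)c(OC)c(OC)c1` has an ethynyl group on that carbonyl carbon instead, and in this assay compound 2 gives 570 nM; the step of a 7.1-fold higher number from compound 1 to compound 2 (0.85 log units; beyond the scatter) is a clear loss of potency. Compound 3 `COc1ccc(CNc2cc(OC)c(OC)c(OC)c2)cc1F` lacks the carbonyl altogether and gives 46200 nM, far weaker than either.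

Compound 4 `C/C=C/C(=O)N(Cc1ccc(OC)c(O)c1)c1cc(OC)c(OC)c(OC)c1` has not yet been measured. It differs from compound 1 as follows: prop-1-en-1-yl in place of cyclopropyl on a carbonyl carbon. Within the data shown here, the only measured step that bears on this change is the one from compound 1 to compound 2, where replacing the cyclopropyl with another unsaturated carbon group cost a modest but real amount of potency. A similar direction is expected here, perhaps somewhat smaller since the prop-1-en-1-yl group, like cyclopropyl, keeps three carbons. For compound 4 the expected step is a 3.1-fold higher number from compound 1 to compound 4 (0.49 log units; beyond the scatter). Compound 4 is therefore estimated at 250 nM, with a range from 80 nM to 800 nM.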

Compound 4, half-maximal inhibitory concentration: 67 nM
Beside the measured number, compound 4's estimate is 3.7-fold (0.57 log units) above it; measured number below the stated range.
By their numbers in this assay, from the lowest: compounds 4 and 1 (each within the scatter of the next); then compound 2; then compound 3.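

In this assay, the closed cyclopropyl ring can be swapped for the open prop-1-en-1-yl chain on this carbonyl carbon without a readable change in potency, as the step is a 1.2-fold lower number from compound 1 to compound 4 (0.08 log units; within the scatter). A double bond outside a ring is therefore tolerated here, and the earlier loss belongs to the ethynyl group rather than to every unsaturated group, with a step of an 8.5-fold lower number from compound 2 to compound 4 (0.93 log units; beyond the scatter), beyond the usual scatter. Nothing available explains why ethynyl stands apart from the other two groups.

The compounds shown leave open how a saturated open chain such as propyl, or a larger ring such as cyclohexyl, would fare on this carbonyl carbon. They also leave open whether a longer chain ending in an amine would be accepted at this place.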